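The source may hold more compounds than are shown below. What is called first, only, known or untested is meant among the compounds shown, and "the series" means these compounds.

Measured so far:
compound 1 `c1ccc(-c2ccc(-c3ccc(-c4nc5ccccc5[nH]4)cc3)cc2)cc1` gives 100000 nM
compound 2 `Cc1ccc2[nH]c(-c3ccc(-c4ccc(-c5ccccc5)cc4)cc3)nc2c1` gives 39300 nM

In a functional assay on HOP-62 cells (Homo sapiens) for inhibition, read by sulforhodamine B assay (on this read-out lower numbers stand for stronger inhibition of growth and higher numbers for weaker inhibition of growth), compound 2 gives 39300 nM as the lower of the two numbers in hand, against compound 1 at 100000 nM in the same read-out. Compound 3 `Cc1ccc2[nH]c(-c3ccc(-c4ccc(-c5ccc(O)cc5)cc4)cc3)nc2c1` carries one change from compound 2: hydroxy in place of hydrogen on an aromatic carbon (hydroxy in place of hydrogen on an aromatic carbon, para to a large group).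

Among the measured compounds shown here, the only measured step is a 2.5-fold lower number from compound 1 to compound 2 (0.41 log units; beyond the scatter) and it is modest. That step introduces a methyl and not a hydroxy, so it gives only a rough size for a single change on an aromatic carbon in this series. For the measured compounds named here, no hydroxy compound has been measured yet, and the direction rests on little. A step of similar modest size is expected, toward a lower number, while no change beyond the scatter remains possible. The expected step is a 1.8-fold lower number from compound 2 to compound 3 (0.25 log units; within the scatter) in this estimate. In this assay the estimate for compound 3 is 22000 nM with an expected range from 7000 nM to 70000 nM on this read-out.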

Compound 3, concentration for 50% growth inhibition: 41200 nM
Compound 3: middle estimate off by 1.9-fold (0.27 log units), on the low side; the range from low to high includes it.
By their numbers in this assay, from the lowest: compounds 2 and 3 (each within the scatter of the next); then compound 1.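

In this assay, phenyl to 4-hydroxyphenyl gives a 1.0-fold higher number from compound 2 to compound 3 (0.02 log units; within the scatter), so at this place, on an aromatic carbon para to a large group, hydroxy and hydrogen cannot be told apart by this read-out. Among the compounds shown here, this is the first reading at this position, and it is separate from the methyl step, a 2.5-fold lower number from compound 1 to compound 2 (0.41 log units; beyond the scatter), which lies beyond the scatter but sits elsewhere on the shared core. The size of that methyl step therefore does not carry over to this position or to hydroxy, and the series now holds one step beyond the scatter and one within it, each at its own place. No supporting evidence bears on why hydroxy reads this way here.

The compounds shown leave open whether a methoxy, an amine or a carboxylic acid at this same position would stay within the scatter of compound 2 or move the number in either direction. They also leave open whether hydroxy would read the same on the core of compound 1, without the methyl, and whether a hydroxy placed on another ring of the shared core would behave as it does here.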